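Compound 3 and a (1-carboxy-2-methylbutyl)amino swap

A few compounds are considered here, and "the series" means these few. Any claim that something is new, unique, unknown or untested is made for them only; others in the source may bear on it.

Compound 1 `CCOC(=O)CN(C)C(=O)c1ccc(C(CC)(CC)c2ccc(OCC(O)C(C)(C)C)c(C)c2)n1CC` gives 10100 nM
Compound 2 `C#CCNC(=O)c1ccc(C(CC)(CC)c2ccc(OCC(O)C(C)(C)C)c(C)c2)n1CC` gives 4400 nM
Compound 3 `CCn1c(C(=O)N(CCC#N)CCC#N)ccc1C(CC)(CC)c1ccc(OCC(O)C(C)(C)C)c(C)c1` gives 1700 nM

In an ADME assay on L02 cells (Homo sapiens) for cytotoxicity, read by MTT assay, with a stated time of 48 h (on this read-out lower numbers stand for stronger inhibition and higher numbers for weaker inhibition), compound 3 has the lowest number of the three. Compound 4 `CC[C@@H](C)[C@H](NC(=O)c1ccc(C(CC)(CC)c2ccc(OCC(O)C(C)(C)C)c(C)c2)n1CC)C(=O)O` differs from it on a carbonyl carbon whose other neighbours are: aromatic carbon, where (1-carboxy-2-methylbutyl)amino enters: a group of 9 heavy atoms (6 carbon, 1 nitrogen, 2 oxygen; no ring) in place of a group of 9 heavy atoms (6 carbon, 3 nitrogen; no ring), on a carbonyl carbon. All three measured steps are changes at this carbonyl carbon: a 2.3-fold lower number from compound 1 to compound 2 (0.36 log units; beyond the scatter), a 5.9-fold lower number from compound 1 to compound 3 (0.77 log units; beyond the scatter) and a 2.6-fold lower number from compound 2 to compound 3 (0.41 log units; beyond the scatter). Each is modest, and compound 3 sits at the low end (1700 nM). Going by the values given here, no measured compound carries the entering group, so a modest move back up is expected. The estimated change is a 2.9-fold higher number from compound 3 to compound 4 (0.47 log units; beyond the scatter) in this assay. For compound 4 the expected value is 5000 nM, with an estimated range from 1800 nM to 15000 nM.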

Compound 4, half-maximal inhibitory concentration: 1400 nM
For compound 4 the middle estimate is 3.6-fold (0.55 log units) above the measured one; measured number below the stated range.
By their numbers in this assay, from the lowest: compounds 4 and 3 (each within the scatter of the next); then compound 2; then compound 1.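

In this assay, two very different groups on this carbonyl carbon give values that cannot be told apart: a 1.2-fold lower number from compound 3 to compound 4 (0.08 log units; within the scatter). The group in compound 4 has no triple bond and brings hydrogen-bond donors, so the low end of this series is not tied to the two nitrile arms of compound 3. The other two steps are larger, a 3.1-fold lower number from compound 2 to compound 4 (0.50 log units; beyond the scatter) and a 7.2-fold lower number from compound 1 to compound 4 (0.86 log units; beyond the scatter), and no measurement explains them. Open, from the compounds shown here alone, is whether the carboxylic acid of compound 4 matters, which a methyl ester or an amine in its place could test. Going by these compounds, the role of its two defined stereocentres also remains open.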